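From 4-chlorophenyl to 3,4-difluorophenyl: an expected small step

The source may hold more compounds than are shown below. What is called first, only, known or untested is meant among the compounds shown, and "the series" means these compounds.

- Compound 1 `COc1ccc(S(=O)(=O)N2CCc3cccc(Nc4ccc(O)cc4)c32)cc1` gives 493 nM
- Compound 2 `COc1ccc(S(=O)(=O)N2CCc3cccc(Nc4ccc(Cl)cc4)c32)cc1` gives 463 nM

Compound 2 stands level with compound 1 in a functional assay on MKN-45 cells (Homo sapiens) for antiproliferative activity (a lower number here means a stronger inhibitor, a higher number a weaker inhibitor), and neither can be ranked above the other. Compound 3 `COc1ccc(S(=O)(=O)N2CCc3cccc(Nc4ccc(F)c(F)c4)c32)cc1` is still unmeasured. It carries 3,4-difluorophenyl in place of 4-chlorophenyl on a nitrogen on an aromatic ring, counted as 3,4-difluorophenyl in place of 4-chlorophenyl on a nitrogen on an aromatic ring and leaving the rest of the structure unchanged. Among the compounds with values here, the only measured step that bears on this is a 1.1-fold lower number from compound 1 to compound 2 (0.03 log units; within the scatter) and it is a change on that same ring. Within the data shown here, no measured compound here carries fluorine, which makes this thin evidence. From that one small step, no change beyond the scatter is expected in this assay and no direction is favoured. The expected step is a 1.0-fold lower number from compound 2 to compound 3 (0.01 log units; within the scatter) by this estimate. For compound 3 the estimated value is 450 nM with an expected range from 170 nM to 1200 nM.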

Compound 3, half-maximal inhibitory concentration: 726 nM
Estimate against measurement, compound 3: 1.6-fold (0.21 log units) below, and the stated range covers the measured number.
By their numbers in this assay, from the lowest: compounds 2, 1 and 3 (each within the scatter of the next).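

In this assay, adding a second ring substituent and bringing in fluorine still produces no clear change: there is a 1.6-fold higher number from compound 2 to compound 3 (0.20 log units; within the scatter), and a 1.5-fold higher number from compound 1 to compound 3 (0.17 log units; within the scatter). The group on this nitrogen now spans 4-hydroxyphenyl, 4-chlorophenyl and 3,4-difluorophenyl, and all three compounds lie within the scatter of one another. This position therefore tolerates all three of these rings in this assay, and the set gives no basis for ranking them.

From the compounds shown here alone, all three groups are phenyl rings carrying hydroxy, chloro or fluoro substituents, so it remains open whether an amine, a carboxylic acid or a longer chain on this ring would shift the number beyond the scatter. Why these three rings give such similar numbers also remains open, as no supporting evidence bears on it.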